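Working notes: terminal group on the chain of the shared core

A few compounds are considered here, and "the series" means these few. Any claim that something is new, unique, unknown or untested is made for them only; others in the source may bear on it.

Measured so far in a functional assay on MCF7 cells (Homo sapiens) for cytotoxicity, read by MTT assay, with a stated time of 72 h; a higher number here means a weaker inhibitor, a lower number a stronger inhibitor:
compound 1 `CN1CCN(CCCCCCn2c3c(c4ccccc42)C(=O)c2c[n+]([O-])c4ccccc4c2C3=O)CC1` gives 400 nM
compound 2 `O=C1c2c[n+]([O-])c3ccccc3c2C(=O)c2c1c1ccccc1n2Cc1cn(C[C@@H](O)CO)nn1` gives 600 nM
compound 3 `CN1CCN(CCCn2c3c(c4ccccc42)C(=O)c2c[n+]([O-])c4ccccc4c2C3=O)CC1` gives 220 nM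

Compound 3 has the lowest number of the three; the two steps that end at it are a 1.8-fold lower number from compound 1 to compound 3 (0.26 log units; within the scatter) and a 2.7-fold lower number from compound 2 to compound 3 (0.44 log units; beyond the scatter). Compound 4 `O=C1c2c[n+]([O-])c3ccccc3c2C(=O)c2c1c1ccccc1n2Cc1cn(C[C@H](O)CO)nn1` differs from compound 3 as follows: 1-(2,3-dihydroxypropyl)-1H-1,2,3-triazol-4-yl in place of 2-(4-methylpiperazin-1-yl)ethyl on a saturated chain carbon bound to an aromatic nitrogen. The change enters the same group that compound 2 carries, with the other configuration at the defined stereocentre, so the step from compound 2 to compound 3 is the step that bears on it, read in reverse. The expected step is therefore a 2.7-fold higher number from compound 3 to compound 4 (0.44 log units; beyond the scatter), a modest rise toward the number of compound 2. Compound 4 is estimated at 600 nM, with a range from 300 nM to 1200 nM.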

Compound 4, half-maximal inhibitory concentration: > 1000 nM
Compound 4: only a limit was reported (the forecaster's own chance of this, stated with the estimate: 5%); middle value at least 1.6-fold (0.22 log units) from the limit.
By their numbers in this assay, from the lowest: compounds 3, 1 and 2 (each within the scatter of the next, the first and the last beyond it). At a limit, above all of these: compound 4.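

Compound 4 gives > 1000 nM in this assay and this is a limit only. The 1-(2,3-dihydroxypropyl)-1H-1,2,3-triazol-4-yl group now stands beyond the scatter from both 4-methylpiperazin-1-yl compounds, with an at least 4.5-fold higher number from compound 3 to compound 4 (0.65 log units; beyond the scatter) and with an at least 2.5-fold higher number from compound 1 to compound 4 (0.39 log units; beyond the scatter) as the second step, where compound 1 and compound 2 alone had not separated. With an at least 1.6-fold higher number from compound 2 to compound 4 (0.22 log units; that floor lies within the scatter) the role of the stereocentre stays unsettled, and this comparison rests on one fact: the fact that compounds 2 and 4 differ only in the configuration as drawn.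

Open, from the compounds shown here alone, is how the triazole would read with a primary amine in place of the diol. Also open, going by these compounds, is how a morpholine compares with 4-methylpiperazin-1-yl at the end of the chain.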